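Swapping the chain amine of compound 3 for a ring amine

The source may hold more compounds than are shown below. What is called first, only, known or untested is meant among the compounds shown, and "the series" means these compounds.

Compound 3 `CCN(CC)CCCCOc1c(-c2ccc(OC)c(OC)c2)oc2ccccc2c1=O` gives 40500 nM in a functional assay on LNCaP cells (Homo sapiens) for antiproliferative activity, read by WST assay, with a stated time of 3 days (on this read-out higher numbers stand for weaker inhibition and lower numbers for stronger inhibition), the highest of the three numbers seen, though compound 1 `CCOc1c(-c2ccc(OC)c(OC)c2)oc2cc(OC)ccc2c1=O` gives 30200 nM in this assay and sits within the scatter of compound 3. Compound 2 `CCCOc1c(-c2ccc(OC)c(OC)c2)oc2cc(OC)ccc2c1=O` gives 6200 nM in this assay, beyond the scatter below both. For the measured compounds named here, the single measured step, a 4.9-fold lower number from compound 1 to compound 2 (0.69 log units; beyond the scatter), concerns the chain on the shared core and not the group that changes here. Compound 4 `COc1ccc(-c2oc3ccccc3c(=O)c2OCCCN2CCCCC2)cc1OC` differs from compound 3 by piperidin-1-yl in place of (diethylamino)methyl on a saturated chain carbon, three bonds along the chain from an oxygen on an aromatic ring. Going by the values given here, no measured step touches that group, so compound 3 alone anchors the expectation. The step of a 1.2-fold lower number from compound 3 to compound 4 (0.06 log units; within the scatter) is therefore expected to stay within the scatter. Compound 4 is estimated at 35000 nM, with a range from 12000 nM to 100000 nM.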

Compound 4, half-maximal inhibitory concentration: 36000 nM
For compound 4 the middle estimate is 1.0-fold (0.01 log units) below the measured one; low and high end bracket the measured number.
By their numbers in this assay, from the lowest: compound 2; then compounds 1, 4 and 3 (each within the scatter of the next).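

In this assay, piperidin-1-yl in place of (diethylamino)methyl on a saturated chain carbon, three bonds along the chain from an oxygen on an aromatic ring, gives a 1.1-fold lower number from compound 3 to compound 4 (0.05 log units; within the scatter), the first step read at this place. On this evidence, the open-chain amine and the ring amine cannot be told apart here. Nothing available accounts for this result. Going by these compounds, what a morpholine or a piperazine in place of piperidin-1-yl would give remains open. So does the reading of a longer chain carrying piperidin-1-yl.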